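The source may hold more compounds than are shown below. What is called first, only, known or untested is meant among the compounds shown, and "the series" means these compounds.

Measured compounds:
compound 1 `O=C1C(Nc2ccccc2F)=CC(=O)c2c1nc1n2[C@H]2OC[C@@H](O)[C@H]2OC1` gives 2660 nM in a functional assay on ECa-109 cells for inhibition, with ECa-109 cell line (Homo sapiens) as the target, read by sulforhodamine B assay; on this read-out higher numbers stand for weaker inhibition and lower numbers for stronger inhibition;
compound 3 `COc1ccc(NC2=CC(=O)c3c(nc4n3[C@H]3OC[C@@H](O)[C@H]3OC4)C2=O)cc1` gives 3410 nM;
compound 2 `O=C1C=C(NC2CCCC2)C(=O)c2c1nc1n2[C@H]2OC[C@@H](O)[C@H]2OC1` gives > 16000 nM, a limit of the assay rather than a number.

Compound 2 thus stands at the limit of > 16000 nM in this assay, at which 1 of the 3 values shown sits, the weakest end of what the assay reports. Compound 4 `COc1cccc(NC2=CC(=O)c3nc4n(c3C2=O)[C@H]2OC[C@@H](O)[C@H]2OC4)c1` differs from it in one place: 3-methoxyphenyl in place of cyclopentyl on an amine nitrogen. For the measured compounds named here, no measured step matches this change directly. Going by the values given here, the one measured step, a 1.3-fold higher number from compound 1 to compound 3 (0.11 log units; within the scatter), shows that the two aryl amines give similar numbers, while compound 2 with cyclopentyl gives only a limit. Compound 4 is therefore expected to move toward the aryl amines, with an estimated step of an at least 4.5-fold lower number from compound 2 to compound 4 (0.66 log units; beyond the scatter). Compound 4 is estimated at 3500 nM, within 1500 nM to 9000 nM.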

Compound 4, half-maximal inhibitory concentration: 7620 nM
Compound 4: middle estimate off by 2.2-fold (0.34 log units), on the low side; low and high end bracket the measured number.
By their numbers in this assay, from the lowest: compounds 1 and 3 (each within the scatter of the next); then compound 4. At a limit, above all of these: compound 2.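

Putting 3-methoxyphenyl in place of cyclopentyl on the amine nitrogen gives an at least 2.0-fold lower number from compound 2 to compound 4 (0.32 log units; beyond the scatter) and so turns an unreadable result into a real number. From the compounds shown here alone, an aromatic ring at this position can therefore give measurable inhibition where this saturated ring did not, but the full size of the step remains unknown. The value of compound 2 is only a limit of the assay: the limit of > 16000 nM in this assay, at which 1 of the 4 values shown sits.

Still open, going by these compounds, is whether the ring alone matters or the methoxy group also contributes. A plain phenyl or a straight butyl chain on the same nitrogen would help separate these.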